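The source may hold more compounds than are shown below. What is called first, only, known or untested is meant among the compounds shown, and "the series" means these compounds.

Working notes on the series. Compound 1 `COc1cc(/C=C/C2CC=CC(=O)O2)cc(OC)c1` in a functional assay on HT-29 cells (Homo sapiens) for inhibition, read by sulforhodamine B assay, with a stated time of 48 h (on this read-out higher numbers stand for weaker inhibition of growth and lower numbers for stronger inhibition of growth), gives 8.2 uM. Compound 2 `COc1cc(/C=C/C2CC=CC(=O)O2)cc(OC)c1OC` in this assay gives 18.8 uM. The step of a 2.3-fold higher number from compound 1 to compound 2 (0.36 log units; beyond the scatter) corresponds to the change (methoxy in place of hydrogen on an aromatic carbon). Compound 3 `COc1ccc(/C=C/C2CC=CC(=O)N2)cc1OC` rests on another core; the difference between the two cores is not broken down here. In this assay compound 3 reaches only a limit of the assay, > 964 uM, the limit being (the limit of > 964 uM in this assay, at which 1 of the 3 values shown sits). Compound 4 `COc1cc(OC)c(OC)cc1/C=C/C1CC=CC(=O)N1` is not yet measured and differs from compound 3 by methoxy in place of hydrogen on an aromatic carbon. This is the same kind of change as from compound 1 to compound 2, though the surroundings differ: here the entering methoxy is ortho to a group of 9 heavy atoms, meta to a methoxy group and para to a methoxy group, whereas in compound 2 it is ortho to two methoxy groups and para to a group of 9 heavy atoms. A step that the limit leaves unreadable from compound 3 to compound 4 is expected, resting on a 2.3-fold higher number from compound 1 to compound 2 (0.36 log units; beyond the scatter) and on compound 3 sitting at a limit with > 964 uM. Compound 4 is estimated at 1500 uM, between 500 uM and 5000 uM, most likely again reported only as a limit.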

Compound 4, concentration for growth inhibition (reported as GI): > 864 uM
Compound 4: only a limit was reported (the forecaster's own chance of this, stated with the estimate: 85%); the middle value is on the limit's open side.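

Compound 3 and compound 4 are both reported only as limits of the assay, and the step between them cannot be read. The compounds shown leave open how the added methoxy acts on this core in this assay.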